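Swapping Chloro for Bromo at a Limit

The source may hold more compounds than are shown below. What is called first, only, known or untested is meant among the compounds shown, and "the series" means these compounds.

In an ADME assay on HepG2 cells (Homo sapiens) for cytotoxicity, read by luminescence, with a stated time of 72 h (a higher number here means that more compound is needed for the effect, a lower number that less compound is needed), compound 1 (`CCOC(=O)c1c(-c2cccc(OC(F)(F)F)c2)[nH]c2cc(OC)ccc2c1=O`) gives > 21500 nM, which is a limit of the assay and not a number. Compound 2 (`CCOC(=O)c1c(-c2cccc(Cl)c2)[nH]c2cc(OC)ccc2c1=O`) gives > 21500 nM, again only a limit. Among the measured compounds shown here, the one measured step that bears on what follows is a step that the two limits leave unreadable from compound 1 to compound 2, so it offers no size to carry forward. Compound 3 (`CCOC(=O)c1c(-c2cccc(Br)c2)[nH]c2cc(OC)ccc2c1=O`) has not yet been measured. The change that leads to it from compound 2 is bromo in place of chloro on an aromatic carbon, meta to a large group. Given (the limit of > 21500 nM in this assay, at which 2 of the 2 values shown sit), compound 3 is expected to sit at or near that same limit, with no step beyond the usual scatter. The expected change is a step that the limit leaves unreadable from compound 2 to compound 3. For compound 3 the estimated value is 30000 nM, with an expected range from 15000 nM to 60000 nM.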

Compound 3, half-maximal effective concentration: > 21500 nM
Compound 3 was reported as a limit; the forecaster's own chance of this, stated with the estimate: 85%; the middle value lies beyond the limit too.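

No step can be read between compound 1, compound 2 and compound 3, since each value is a limit and not a number: the limit of > 21500 nM in this assay, at which 3 of the 3 values shown sit.

The compounds shown leave open how much of each is needed for the effect, and so whether trifluoromethoxy, chloro and bromo differ at all.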